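Removing the substituted aryl urea: a smaller benzamide

The source may hold more compounds than are shown below. What is called first, only, known or untested is meant among the compounds shown, and "the series" means these compounds.

Of the compounds shown here, two on a shared core have been tested in a functional assay on BT-549 cells (Homo sapiens) for inhibition, read by sulforhodamine B assay, with a stated time of 48 h; a higher number here means a weaker inhibitor of growth, a lower number a stronger inhibitor of growth. Compound 1 `COc1cc(-c2nn(-c3cccc(NC(=O)c4ccc(Cl)c(C(F)(F)F)c4)c3)cc2-c2ccncc2)ccc1Cl` carries an amide whose carbonyl bears a 4-chloro-3-(trifluoromethyl)phenyl group; in this assay compound 1 gives 7540 nM. Compound 2 `COc1cc(-c2nn(-c3cccc(NC(=O)Nc4ccc(Cl)c(C(F)(F)F)c4)c3)cc2-c2ccncc2)ccc1Cl` instead has a urea, with (4-chloro-3-(trifluoromethyl)phenyl)amino on the carbonyl carbon, and compound 2 gives 2360 nM. Within the data shown here, that change is the only measured step: a 3.2-fold lower number from compound 1 to compound 2 (0.50 log units; beyond the scatter). Compound 2 therefore stands with the lowest number of the two, its nearest neighbour being compound 1.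

Compound 3 `COc1cc(-c2nn(-c3cccc(NC(=O)c4ccccc4)c3)cc2-c2ccncc2)ccc1Cl` is not yet measured. It differs from compound 2 in one place: phenyl in place of (4-chloro-3-(trifluoromethyl)phenyl)amino on a carbonyl carbon. This step undoes the urea-to-amide change seen between compound 1 and compound 2 and also strips the chloro and trifluoromethyl groups from the ring. The measured step from compound 1 to compound 2 bears on it directly, and since that step lowered the number, moving back to an amide is expected to raise it, beyond the scatter. For compound 3 the estimate is 15000 nM, within 5000 nM to 50000 nM. This means an expected step of a 6.4-fold higher number from compound 2 to compound 3 (0.80 log units; beyond the scatter).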

Compound 3, concentration for 50% growth inhibition: 1330 nM
The estimate for compound 3 lay 11-fold (1.05 log units) above the measured number, and the stated range ends above it.
By their numbers in this assay, from the lowest: compounds 3 and 2 (each within the scatter of the next); then compound 1.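

In this assay the step of a 1.8-fold lower number from compound 2 to compound 3 (0.25 log units; within the scatter) means that compound 2 and compound 3 cannot be told apart, even though the large (4-chloro-3-(trifluoromethyl)phenyl)amino group on the carbonyl carbon has given way to a plain phenyl. Within the amides, the change to phenyl gives a 5.7-fold lower number from compound 1 to compound 3 (0.75 log units; beyond the scatter) and so shows that the unsubstituted amide sits clearly lower than the one carrying chloro and trifluoromethyl, which means a urea is not needed at this place for a number in the range of compound 2. No measurement shown here accounts for these differences.

Chloro and trifluoromethyl left the ring together, so these compounds do not separate what each contributes, and a ring carrying only one of them would address that. From the compounds shown here alone, it also remains open whether a polar group such as an amine or a carboxylic acid on this phenyl ring, or a urea ending in plain phenyl, would keep the number in this range.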